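A few compounds are considered here, and "the series" means these few. Any claim that something is new, unique, unknown or untested is made for them only; others in the source may bear on it.

Series notes. Compound 1 `CN1CCN(c2ccc(NC(=N)c3cc4cn[nH]c4cn3)cc2)CC1` and compound 2 `CN1CCN(c2ccc(NC(=N)c3cc4cnn(C)c4cn3)cc2)CC1` share the same core and the same amidine-linked aryl piece bearing a methylpiperazine; compound 2 differs from compound 1 by methyl in place of hydrogen on an aromatic nitrogen. In a functional assay on PC-3 cells (Homo sapiens) for cytotoxicity, read by MTT assay, with a stated time of 72 h (on this read-out higher numbers stand for weaker inhibition and lower numbers for stronger inhibition), compound 1 gives 45400 nM. In this assay compound 2 gives 32300 nM. The step of a 1.4-fold lower number from compound 1 to compound 2 (0.15 log units; within the scatter) lies within the scatter, so no order between compound 1 and compound 2 is claimed.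

Compound 3 `N=C(Nc1cccc(C(F)(F)F)c1)c1cc2cn[nH]c2cn1` keeps the shared core but carries a trifluoromethyl-substituted aryl piece in place of the one bearing the methylpiperazine; the difference between compound 1 and compound 3 is not broken down here. In this assay compound 3 returns only a limit, > 50000 nM, not a number. This is the limit of > 50000 nM in this assay, at which 1 of the 3 values shown sits.

Compound 4 `Cn1ncc2cc(C(=N)Nc3cccc(C(F)(F)F)c3)ncc21` is not yet measured. It stands to compound 3 as compound 2 stands to compound 1, by methyl in place of hydrogen on an aromatic nitrogen, the same kind of change at the same kind of place. For the measured compounds named here, the one measured instance of this change, a 1.4-fold lower number from compound 1 to compound 2 (0.15 log units; within the scatter), is within the scatter. On that basis the corresponding step in this assay is expected to be small, an at least 1.1-fold lower number from compound 3 to compound 4 (0.04 log units; that floor lies within the scatter). Because compound 3 gives only the limit > 50000 nM in this assay, a second limit rather than a number is the more likely outcome for the methylated analogue. The estimate for compound 4 in this assay is 45000 nM, expected to fall between 22000 nM and 100000 nM.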

Compound 4, half-maximal inhibitory concentration: 50000 nM
Compound 4: middle estimate off by 1.1-fold (0.05 log units), on the low side; measured number inside the range.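

Set side by side, the methyl in place of hydrogen on an aromatic nitrogen on two cores in this assay reads: the same change on two cores in this assay, a 1.4-fold lower number (0.15 log units; within the scatter) from compound 1 to compound 2 and a number no higher (the limit leaves the size open) from compound 3 to compound 4; the limit leaves it open whether they differ

For compound 3 the reading is a limit, not a number: > 50000 nM. For the compounds shown here, on this core the step is a number no higher from compound 3 to compound 4 (the limit leaves the size open) and its size therefore cannot be read, so the comparison shows only that neither core gives a higher number with the methyl, and it does not show that the change carries over with the same size. With one readable step, which lies within the scatter, and one open step, these two pairs support no rule for the series beyond compounds 1 to 4.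

The compounds shown leave open what an ethyl group or a longer chain would do on that aromatic nitrogen, where only hydrogen and methyl appear here. They also leave open whether the same change behaves alike on an aryl piece carrying a morpholine or a carboxylic acid in place of the methylpiperazine or the trifluoromethyl.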